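This account rests on a few compounds, and the source may have more. Where it says the series, first, only, none or still open, it means among the compounds named here.

Working notes on the series.

Among the measured compounds shown here, compound 1 `Cc1ccc(SCc2ccc(/C=C/C(=O)Nc3ccccc3N)cc2)cc1` stands lowest of the three numbers measured so far. In a functional assay on A549 cells (Homo sapiens) for inhibition, read by CCK-8 assay, with a stated time of 72 h, tested at 2 uM (on this read-out lower numbers stand for less inhibition of growth and higher numbers for more inhibition of growth at the one concentration tested), compound 1 gives 43.4%. Compound 2 `Nc1ccccc1NC(=O)/C=C/c1ccc(CSc2ccc(F)cc2)cc1` gives 51.2% in this assay, and compound 3 `Nc1ccccc1NC(=O)/C=C/c1ccc(CSc2cccc(F)c2)cc1` gives 50.7%. The three lie close: a number 7.8 percentage points higher from compound 1 to compound 2 (within the scatter), a number 7.3 percentage points higher from compound 1 to compound 3 (within the scatter), and a number 0.5 percentage points lower from compound 2 to compound 3 (within the scatter). None of these steps leaves the scatter, so on the numbers shown compound 1 cannot be called weaker than compound 2 or compound 3.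

Compound 4 `Nc1ccccc1NC(=O)/C=C/c1ccc(CSc2ccc(C(F)(F)F)cn2)cc1` has not been measured. It differs from compound 1 in one place: 5-(trifluoromethyl)pyridin-2-yl in place of 4-methylphenyl on a sulfur. The group on the sulfur is exactly the place varied in all three measured steps, so each of them bears on this change. Swapping 4-methylphenyl for 4-fluorophenyl or 3-fluorophenyl moved the read-out only within the scatter, and moving fluorine between the two fluorophenyl groups did nothing. The entering 5-(trifluoromethyl)pyridin-2-yl is a larger departure, with a ring nitrogen and a trifluoromethyl, than anything measured here, so the precedent is thin. The expected step is a number 6.6 percentage points higher from compound 1 to compound 4 (within the scatter), a modest rise that stays within the scatter. In this assay compound 4 is estimated at 50%, with a range from 33% to 67%.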

Compound 4, percent growth inhibition at one concentration: 51.7%
Beside the measured number, compound 4's estimate is 1.7 percentage points below it; the range from low to high includes it.
By their numbers in this assay, from the lowest: compounds 1, 3, 2 and 4 (each within the scatter of the next).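

So far the group on the sulfur had been varied only among phenyl rings of carbon alone, each carrying a methyl or a fluoro. 5-(Trifluoromethyl)pyridin-2-yl now extends that range to a ring with a hetero atom, a hydrogen-bond acceptor and a trifluoromethyl, and in this assay the comparisons show a number 8.3 percentage points higher from compound 1 to compound 4 (within the scatter), a number 1 percentage points higher from compound 3 to compound 4 (within the scatter) and a number 0.5 percentage points higher from compound 2 to compound 4 (within the scatter), so this change cannot be told apart from any of the three earlier groups on the sulfur. No measurement bearing on why the read-out stays so close is available, and the single tested concentration gives no ordering among these four compounds.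

The two parts of the entering group remain unseparated, since neither an unsubstituted pyridin-2-yl nor a 4-(trifluoromethyl)phenyl appears among the compounds shown, so the ring nitrogen and the trifluoromethyl cannot be judged one at a time. Also open, going by these compounds, is whether this position stays as permissive with something further from an aromatic ring on the sulfur, such as a cyclohexyl, a longer alkyl chain or a chain ending in an amine or a carboxylic acid.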